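Methoxy in place of chloro: another limit expected

A few compounds are considered here, and "the series" means these few. Any claim that something is new, unique, unknown or untested is made for them only; others in the source may bear on it.

Compound 1 `CCOc1ccc2nc(Cl)c(/C=C3\SC(=S)NC3=O)cc2c1`: > 100 ug/mL
Compound 2 `O=C1NC(=S)S/C1=C\c1cc2cc(Cl)ccc2nc1Cl`: > 100 ug/mL
Compound 3 `Cc1cccc2cc(/C=C3\SC(=S)NC3=O)c(Cl)nc12`: > 100 ug/mL

In a toxicity assay on PANC-1 cells (Homo sapiens) for cytotoxicity, read by MTT assay, with a stated time of 48 h (on this read-out lower numbers stand for stronger inhibition of growth and higher numbers for weaker inhibition of growth), compound 1 gives > 100 ug/mL, which is a limit of the assay and not a number. Compound 2 gives > 100 ug/mL, again a limit. Compound 3 gives > 100 ug/mL, also a limit. Compound 2 therefore stands nowhere in particular on a scale: all three measured values share (the limit of > 100 ug/mL in this assay, at which 3 of the 3 values shown sit), and none of them is a number. Within the data shown here, the one measured step, a step that the two limits leave unreadable from compound 1 to compound 2, joins two limits, so its size cannot be read. Compound 4 `COc1ccc2nc(Cl)c(/C=C3\SC(=S)NC3=O)cc2c1` differs from compound 2 by methoxy in place of chloro on an aromatic carbon. Compound 1 carries an ethoxy group, close in kind to a methoxy group, at that same place and also sits at the limit of > 100 ug/mL in this assay, at which 3 of the 3 values shown sit. The step from compound 2 to compound 4 thus has no readable counterpart, and the closest analogues give no sign that the change pulls the value below the limit. Compound 4 is expected to give 150 ug/mL (range 60 ug/mL to 400 ug/mL). The expected step that the limit leaves unreadable from compound 2 to compound 4 is thus essentially none, and most likely compound 4 will also be reported only as a limit.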

Compound 4, concentration for 50% growth inhibition: > 100 ug/mL
Compound 4: a limit, no number (the forecaster's own chance of this, stated with the estimate: 85%); the middle value does not contradict the limit.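

In this assay compound 4 gives > 100 ug/mL and this is a limit, not a number. Its steps from compound 1 and from compound 2 therefore cannot be read, since every value shown is such a limit: (the limit of > 100 ug/mL in this assay, at which 4 of the 4 values shown sit). The compounds shown leave open how far each lies past that limit, and whether any change to the group on the shared core alters growth inhibition.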